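The source may hold more compounds than are shown below. What is called first, only, known or untested is meant among the compounds shown, and "the series" means these compounds.

Working notes on the series. The compounds share a core in which a five-membered aromatic ring with 1 nitrogen and 1 oxygen carries an aryl group and a methyl group. Compound 1 `Cc1oc(-c2c(Br)cccc2Br)nc1CN1CCC(C(=O)NCCCN2C[C@H](C)C[C@H](C)C2)CC1` is the only one of the three measured compounds for which a number, rather than a limit, has been obtained. In an ADME assay on microsomes from liver (Rattus norvegicus) for metabolic stability, read by LC-MS, using NADPH, at 37 degrees C (a lower number here means that the compound disappears faster, a higher number that the compound lasts longer), compound 1 gives 0.035 h. Compound 2 `CCCN(CCC)CCNC(=O)C1CCN(Cc2nc(-c3ccccc3C)oc2C)CC1` reaches only the limit of this assay, recorded as > 0.5 h. Compound 3 `Cc1ccccc1-c1nc(CN2CCC(C(=O)N3CCN(C4CCN(C)CC4)CC3)CC2)c(C)o1` likewise stops at the limit, recorded as > 0.5 h. Compound 1 therefore stands alone at the short end of what has been measured, while the other two sit at the limit of > 0.5 h in this assay, at which 2 of the 3 values shown sit. Among the compounds with values here, no pair of measured compounds differs in a single place, so no measured step size is available for the series.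

Compound 4 `COc1cccc(C)c1-c1nc(CN2CCC(C(=O)NCCCN3C[C@H](C)C[C@H](C)C3)CC2)c(C)o1` differs from compound 1 in one place: 2-methoxy-6-methylphenyl in place of 2,6-dibromophenyl on an aromatic carbon. The step from compound 1 to compound 4 in this assay is expected to be an increase beyond the usual scatter, of the order of a 5.7-fold higher number from compound 1 to compound 4 (0.76 log units; beyond the scatter). Compound 4 is expected to give about 0.2 h in this assay, with a plausible span from 0.05 h to 0.6 h. A report of only the limit for compound 4 cannot be excluded.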

Compound 4, half-life: 0.0767 h
The estimate for compound 4 lay 2.6-fold (0.42 log units) above the measured number, within the range that was stated.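

This gives the series its first measured step. In this assay, 2-methoxy-6-methylphenyl in place of 2,6-dibromophenyl on an aromatic carbon of the five-membered aromatic ring with 1 nitrogen and 1 oxygen goes with a 2.2-fold higher number from compound 1 to compound 4 (0.34 log units; beyond the scatter), so with the rest of compound 1 unchanged, the aryl group at this position moves the half-life by a modest amount. Compound 4 still gives a number rather than a limit, and the limit remains with other compounds in the series: the limit of > 0.5 h in this assay, at which 2 of the 4 values shown sit.

With a single step, the data cannot say whether the change follows from the methoxy group, the methyl group or the loss of bromine, and a 2,6-dimethylphenyl or 2,6-dimethoxyphenyl group at this position would help to separate these. Also open, on these data alone, is whether a step of this size would carry over to the different amide side chains of compound 2 and compound 3, which differ from compound 4 in more than one place and so allow no direct reading.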